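Replacing a basic piperazine with a sulfamide on the shared core

This account rests on a few compounds, and the source may have more. Where it says the series, first, only, none or still open, it means among the compounds named here.

Measured so far:
- compound 1 `CN1CCN(C[C@H]2CN(c3ccc(-n4cc(-c5ccccn5)cn4)c(F)c3)C(=O)O2)CC1`, 70 ug/mL
- compound 2 `COC(=O)CC1CCN(C[C@H]2CN(c3ccc(-n4cc(-c5ccccn5)cn4)c(F)c3)C(=O)O2)CC1`, > 400 ug/mL

Of the compounds shown here, two sharing the core of compound 1 have been tested in an ADME assay on L02 cells (Homo sapiens) for cytotoxicity, read by MTT assay, with a stated time of 48 h; a lower number here means a stronger inhibitor, a higher number a weaker inhibitor. Going by the values given here, compound 1 gives 70 ug/mL, the only plain number among the values shown. Compound 2 gives a limit of the assay rather than a number, > 400 ug/mL. Of the two values shown, (the limit of > 400 ug/mL in this assay, at which 1 of the 2 values shown sits). Among the compounds with values here, the single measured step is an at least 5.7-fold higher number from compound 1 to compound 2 (0.75 log units; beyond the scatter).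

Compound 3 `CN(C)S(=O)(=O)NC[C@H]1CN(c2ccc(-n3cc(-c4ccccn4)cn3)c(F)c2)C(=O)O1` differs from compound 1 by (dimethylsulfamoyl)amino in place of 4-methylpiperazin-1-yl on a saturated chain carbon bound to a saturated ring carbon. That measured step also removes the 4-methylpiperazin-1-yl group from the same saturated chain carbon, so it bears directly on this change, and it points toward a higher number, that is, weaker inhibition. The incoming (dimethylsulfamoyl)amino group is not the 4-((methoxycarbonyl)methyl)piperidin-1-yl group of compound 2, and the measured step is itself only a lower bound, so the size is uncertain. The step expected for compound 3 is a 3.6-fold higher number from compound 1 to compound 3 (0.55 log units; beyond the scatter). Compound 3 is therefore estimated at 250 ug/mL, with a range from 120 ug/mL to 450 ug/mL.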

Compound 3, half-maximal inhibitory concentration: 158 ug/mL
Compound 3: the middle estimate sits 1.6-fold (0.20 log units) above what was measured; measured number inside the range.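

In this assay, compound 3 puts a group with no ring on the saturated chain carbon bound to a saturated ring carbon, and (dimethylsulfamoyl)amino in place of 4-methylpiperazin-1-yl gives a 2.3-fold higher number from compound 1 to compound 3 (0.35 log units; beyond the scatter) with plain numbers at both ends, so the size of one change away from 4-methylpiperazin-1-yl can now be read rather than only bounded. The two replacements also part from each other, with an at least 2.5-fold lower number from compound 2 to compound 3 (0.40 log units; beyond the scatter) showing that the outcome at this position depends on which group enters and not only on the loss of 4-methylpiperazin-1-yl. For compound 2 the value remains a limit of the assay rather than a number, so the full size of that second step stays unread: the limit of > 400 ug/mL in this assay, at which 1 of the 3 values shown sits.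

The compounds shown do not settle whether an open-chain amine such as dimethylamino on the same chain carbon would read nearer to compound 1 or to compound 3. They also leave open how a carboxylic acid in place of the methyl ester of the 4-((methoxycarbonyl)methyl)piperidin-1-yl group would read, and which part of the (dimethylsulfamoyl)amino group goes with its step.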